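A few compounds are considered here, and "the series" means these few. Any claim that something is new, unique, unknown or untested is made for them only; others in the source may bear on it.

Measured compounds in a functional assay on HL-60 cells (Homo sapiens) for antiproliferative activity, read by CellTiter-Glo, with a stated time of 72 h; a higher number here means a weaker inhibitor, a lower number a stronger inhibitor:
Compound 1, `CO[C@@H]1[C@H](N(C)c2ncc(-c3c[nH]c4ccc(Cl)cc34)s2)C[C@H]2O[C@]1(C)n1c3ccccc3c3c4c(c5c6ccccc6n2c5c31)C(=O)NC4`: in this assay compound 1 gives > 10000 nM, a limit of the assay.
Compound 2, `COc1ccc2[nH]cc(-c3cnc(N(C)[C@@H]4C[C@H]5O[C@@](C)([C@@H]4OC)n4c6ccccc6c6c7c(c8c9ccccc9n5c8c64)C(=O)NC7)s3)c2c1`: in this assay compound 2 gives > 10000 nM, a limit of the assay.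
Compound 3, `CO[C@@H]1[C@H](N(C)c2ncc(-c3c[nH]c4ccccc34)s2)C[C@H]2O[C@]1(C)n1c3ccccc3c3c4c(c5c6cc(Cl)ccc6n2c5c31)C(=O)NC4`: in this assay compound 3 gives > 10000 nM, a limit of the assay.

Compound 3 therefore stands at the same limit as the other two, which is the limit of > 10000 nM in this assay, at which 3 of the 3 values shown sit. Among the compounds with values here, the only step between measured compounds that differ in one place, a step that the two limits leave unreadable from compound 1 to compound 2, cannot be read because both ends sit at that limit, so it gives no size and no direction.

The unmeasured compound 4 is `CO[C@@H]1[C@H](N(C)c2ncc(-c3c[nH]c4ccc(Br)cc34)s2)C[C@H]2O[C@]1(C)n1c3ccccc3c3c4c(c5c6cc(Cl)ccc6n2c5c31)C(=O)NC4`. It differs from compound 3 by bromo in place of hydrogen on an aromatic carbon. Within the data shown here, no measured step bears on this change: the one step between measured compounds concerns a different ring and is itself unreadable. With every shown value at the limit, the expected step is a step that the limit leaves unreadable from compound 3 to compound 4, meaning no movement that the data could show. Compound 4 is therefore estimated to give 15000 nM in this assay, within 4000 nM to 60000 nM, most likely reported again as a limit.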

Compound 4, half-maximal inhibitory concentration: > 10000 nM
Compound 4: no number, only a limit; the forecaster's own chance of this, stated with the estimate: 85%; the middle value does not contradict the limit.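

In this assay compound 4 gives > 10000 nM, a limit of the assay. No step from compound 3 to compound 4 can be read, because both sit at the same limit: the limit of > 10000 nM in this assay, at which 4 of the 4 values shown sit.

The compounds shown leave open whether bromo, chloro or methoxy makes any difference to activity, and which compound of this kind would give a measured number.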